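A few compounds are considered here, and "the series" means these few. Any claim that something is new, unique, unknown or untested is made for them only; others in the source may bear on it.

In a functional assay on HepG2 cells (Homo sapiens) for inhibition, read by MTT assay, with a stated time of 72 h (on this read-out lower numbers stand for stronger inhibition and higher numbers for weaker inhibition), compound 1 `Cc1cc2occ(-c3nc(-c4ccccc4)c(-c4ccccc4)n3-c3ccccc3Cl)c(=O)c2cc1Cl` gives 6250 nM and compound 2 `Cc1cc2occ(-c3nc(-c4ccccc4)c(-c4ccccc4)n3-c3ccc(Cl)c(Cl)c3)c(=O)c2cc1Cl` gives 12500 nM. Compound 2 stands at the higher of the two numbers, but the gap to compound 1, a 2.0-fold higher number from compound 1 to compound 2 (0.30 log units; within the scatter), is within the scatter, so no real difference is claimed. Compound 3 `Cc1cc2occ(-c3nc(-c4ccccc4)c(-c4ccccc4)n3-c3cccc(Cl)c3)c(=O)c2cc1Cl` differs from compound 2 by hydrogen in place of chloro on an aromatic carbon. For the measured compounds named here, the only measured step, a 2.0-fold higher number from compound 1 to compound 2 (0.30 log units; within the scatter), also alters the chloro pattern of the ring on the aromatic nitrogen, and it stayed within the scatter; no step tests this exact change. Compound 3 is therefore expected near compound 2, with a 1.3-fold lower number from compound 2 to compound 3 (0.10 log units; within the scatter) not beyond the scatter, estimated at 10000 nM (range 4000 nM to 25000 nM).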

Compound 3, half-maximal inhibitory concentration: 25000 nM
Estimate against measurement, compound 3: 2.5-fold (0.40 log units) below; the measured number falls inside the stated range.
By their numbers in this assay, from the lowest: compounds 1, 2 and 3 (each within the scatter of the next, the first and the last beyond it).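

In this assay the loss of one chloro group, a 2.0-fold higher number from compound 2 to compound 3 (0.30 log units; within the scatter), stays within the scatter, so 3,4-dichlorophenyl and 3-chlorophenyl are not separated on the aromatic nitrogen. For the compounds shown here, the shift of the single chloro group, a 4.0-fold higher number from compound 1 to compound 3 (0.60 log units; beyond the scatter), is the first step beyond the scatter, though modest, and it shows that the place of the chloro on this ring can matter, with 2-chlorophenyl giving the lower number. No supporting data bear on the origin of this difference.

On these data alone, whether a methoxy group or an amine in place of that chloro would hold the number of compound 1 remains open.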